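Two ketones on the ring amide: from compound 2 to compound 4

A few compounds are considered here, and "the series" means these few. Any claim that something is new, unique, unknown or untested is made for them only; others in the source may bear on it.

Three compounds share one core, an aminothiophene carrying two chlorophenyl groups and an amide, and differ only in what sits on the amide carbonyl. Compound 1 `Nc1sc(-c2ccc(Cl)cc2)c(-c2ccc(Cl)cc2)c1C(=O)N1CCCCC1=O` gives 1820 nM in a functional assay on A549 cells (Homo sapiens) for inhibition, read by sulforhodamine B assay, with a stated time of 72 h; a lower number here means a stronger inhibitor, a higher number a weaker inhibitor. Compound 2 `Nc1sc(-c2ccc(Cl)cc2)c(-c2ccc(Cl)cc2)c1C(=O)NC1CCCCC1` gives 2410 nM, the second highest of the three numbers; compound 1 is its nearest neighbour, and the step of a 1.3-fold higher number from compound 1 to compound 2 (0.12 log units; within the scatter) lies within the scatter. Within the data shown here, compound 3 `CC(C)CNC(=O)c1c(N)sc(-c2ccc(Cl)cc2)c1-c1ccc(Cl)cc1` gives 21000 nM, and the step of an 8.7-fold higher number from compound 2 to compound 3 (0.94 log units; beyond the scatter) is the only clearly resolved change so far, with a 12-fold higher number from compound 1 to compound 3 (1.06 log units; beyond the scatter) pointing the same way.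

Compound 4 `Nc1sc(-c2ccc(Cl)cc2)c(-c2ccc(Cl)cc2)c1C(=O)N1CCC(=O)CC1=O` is not yet measured. Its difference from compound 2 is 2,4-dioxopiperidin-1-yl in place of cyclohexylamino on a carbonyl carbon. Among the measured compounds shown here, the closest precedent is the step from compound 1 to compound 2, where a ring amide and a cyclohexylamide gave numbers within the scatter of each other. For the measured compounds named here, the second ketone of compound 4 has no counterpart among the measured compounds, so the expectation leans on that one step alone. For compound 4 the estimated step of a 1.0-fold higher number from compound 2 to compound 4 (0.02 log units; within the scatter) is expected to stay small. Compound 4 is therefore estimated at 2500 nM, with a range from 900 nM to 7000 nM.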

Compound 4, half-maximal inhibitory concentration: 4090 nM
Compound 4: the middle estimate sits 1.6-fold (0.21 log units) below what was measured; the range from low to high includes it.
By their numbers in this assay, from the lowest: compounds 1, 2 and 4 (each within the scatter of the next, the first and the last beyond it); then compound 3.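

In this assay the second ketone gives the first resolved difference between two ring amides, with a 2.2-fold higher number from compound 1 to compound 4 (0.35 log units; beyond the scatter) for 2,4-dioxopiperidin-1-yl in place of 2-oxopiperidin-1-yl. Against the cyclohexylamide, a 1.7-fold higher number from compound 2 to compound 4 (0.23 log units; within the scatter) shows that a group without the amide hydrogen can match one that has it at this carbonyl carbon, so that hydrogen is not required for a number in this range. Compound 1 and compound 2 had already given lower numbers than the open-chain compound 3. The third ring-bearing group stays apart from isobutylamino too, with a 5.1-fold lower number from compound 3 to compound 4 (0.71 log units; beyond the scatter). All three six-membered ring groups give lower numbers than isobutylamino, and none of the four compounds goes against this.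

As far as these compounds go, how a morpholin-4-yl ring or a longer chain such as hexylamino would fit this pattern remains open. The data offer no measurement that explains these steps.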